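A Hydroxyl for a Methoxy on the Sulfonamide Aryl

The source may hold more compounds than are shown below. What is called first, only, known or untested is meant among the compounds shown, and "the series" means these compounds.

Compound 1, `O=S(=O)(Nc1ccc(-c2nc3ccccc3o2)cc1)c1ccccc1Cl`: in an assay on cells for inhibition of HSP60/HSP10 (Homo sapiens), with a stated time of 60 min (on this read-out higher numbers stand for weaker inhibition and lower numbers for stronger inhibition), compound 1 reaches only the limit of the assay, > 100000 nM.
Compound 2, `COc1cccc(S(=O)(=O)Nc2ccc3oc(-c4ccccc4)nc3c2)c1`: in this assay compound 2 likewise reaches only the limit of the assay, > 100000 nM.

Both measured compounds therefore stand at the same place, (the limit of > 100000 nM in this assay, at which 2 of the 2 values shown sit), and compound 2 is known only as a limit rather than as a number. Among the compounds with values here, no step between two measured compounds is available to show how any change moves the read-out.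

Compound 3, `O=S(=O)(Nc1ccc2oc(-c3ccccc3)nc2c1)c1ccccc1O`, is the next compound to be tested. It differs from compound 2 in one place: 2-hydroxyphenyl in place of 3-methoxyphenyl on a sulfonyl sulfur.

Without a measured step to lean on, the change a number no higher from compound 2 to compound 3 (the limit leaves the size open) is expected to stay within the scatter, leaving compound 3 near where compound 2 stands. Compound 3 is thus estimated at 100000 nM, with a range from 30000 nM to 300000 nM, and most likely reported again only as a limit.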

Compound 3, half-maximal inhibitory concentration: 85000 nM
Estimate against measurement, compound 3: 1.2-fold (0.07 log units) above; the measured number falls inside the stated range.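

In this assay, compound 3 is the first compound shown to give a number rather than a limit, so the aryl group on the sulfonyl sulfur is a place where a change can yield a readable value. From the compounds shown here alone, putting 2-hydroxyphenyl in place of 3-methoxyphenyl gives an at least 1.1-fold lower number from compound 2 to compound 3 (0.07 log units; that floor lies within the scatter), and only the floor of this step is known, so its true size stays open. The other compounds still give no number, and this caps what any comparison can show: the limit of > 100000 nM in this assay, at which 2 of the 3 values shown sit.

The change alters both the group and its number on the ring, so the compounds shown cannot separate the effect of the hydroxyl from that of its location. Going by these compounds, how an amine or a carboxylic acid on this ring would read also remains open.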